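The source may hold more compounds than are shown below. What is called first, only, known or untested is meant among the compounds shown, and "the series" means these compounds.

Compound 2 `NC(=O)c1c(NC(=O)Nc2ccc(Cl)cc2)sc2c1CCCC2` is known only as a limit: in a functional assay (strain AB) with Danio rerio as the target, read by microscopy, with a stated time of 1 h (a higher number here means that more compound is needed for the effect, a lower number that less compound is needed), compound 2 gives > 25000 nM. Compound 1 `CCC1CCc2c(sc(NC(=O)Nc3ccc(Cl)cc3)c2C(N)=O)C1` is likewise only a limit, at > 25000 nM. Compound 3 `C[N+](C)(C)C1CCc2c(sc(NC(=O)Nc3ccc(Cl)cc3)c2C(N)=O)C1` carries a group of 4 heavy atoms (3 carbon, 1 nitrogen; no ring) in place of a hydrogen atom, on a saturated ring carbon. Among the measured compounds shown here, the only measured step bearing on this is a step that the two limits leave unreadable from compound 1 to compound 2, so it offers no size to carry over. In this assay a small gain is tentatively expected, though a result that remains a limit is more likely. The estimated step is an at least 1.2-fold lower number from compound 2 to compound 3 (0.09 log units; that floor lies within the scatter). Compound 3 is expected at 20000 nM, within an estimated range of 3000 nM to 60000 nM.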

Compound 3, half-maximal effective concentration: 5870 nM
The estimate for compound 3 lay 3.4-fold (0.53 log units) above the measured number; the range from low to high includes it.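

Among the compounds shown here, on the saturated ring carbon, the group of 4 heavy atoms with net charge +1 gives the first readable value of the series in this assay, with an at least 4.2-fold lower number from compound 2 to compound 3 (0.62 log units; beyond the scatter). Set against the ethyl group at that carbon, the change gives an at least 4.2-fold lower number from compound 1 to compound 3 (0.62 log units; beyond the scatter), so what this carbon carries can move the number beyond the scatter. The step between compound 1 and compound 2 cannot be read.

From the compounds shown here alone, compound 2 remains a limit, which leaves the full size of these steps open: the limit of > 25000 nM in this assay, at which 2 of the 3 values shown sit. Whether a dimethylamino group or a carboxylic acid on the same carbon would give a similar number also remains open.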